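Cytotoxicity notes on one shared-core series, toward compound 4

The source may report more compounds than this note shows. Statements on the series, on what has been measured and on what is new or still open speak of the compounds shown alone.

Measured compounds, with values from a functional assay on U-251 cells (Homo sapiens) for inhibition, read by sulforhodamine B assay, with a stated time of 48 h; on this read-out higher numbers stand for lower toxicity in this test and lower numbers for higher toxicity in this test:
compound 1, `O=C(Nc1cccc(-n2cc(-c3ccncc3)c(-c3ccc(Cl)c(O)c3)n2)c1)Nc1cccc(C(F)(F)F)c1`: > 32500 nM
compound 2, `COc1cc(-c2nn(-c3cccc(NC(=O)c4cccc(C(F)(F)F)c4)c3)cc2-c2ccncc2)ccc1Cl`: > 50000 nM
compound 3, `O=C(Nc1cccc(-n2cc(-c3ccncc3)c(-c3ccc(Cl)c(O)c3)n2)c1)Nc1ccc(Cl)c(Cl)c1`: > 32500 nM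

Every value shown in this assay is a limit of the assay and not a number. Compound 2 stands at the limit of > 50000 nM in this assay, at which 1 of the 3 values shown sits. Compound 1 and compound 3 stand at the limit of > 32500 nM in this assay, at which 2 of the 3 values shown sit. Among the compounds with values here, the only step between measured compounds that differ in one place, a step that the two limits leave unreadable from compound 1 to compound 3, is therefore unreadable.

The step toward compound 4, `COc1cc(-c2nn(-c3cccc(NC(=O)Nc4cccc(C(F)(F)F)c4)c3)cc2-c2ccncc2)ccc1Cl`, is (3-(trifluoromethyl)phenyl)amino in place of 3-(trifluoromethyl)phenyl on a carbonyl carbon. Within the data shown here, no measured step bears on this change directly: the one measured step runs between two limits and has no readable size, and the values of compound 1 and compound 3, whose carbonyl carbon also carries an amino group, are limits as well. The expectation for compound 4 in this assay is thus no step beyond the scatter, and most likely another limit; the expected step is a number no higher from compound 2 to compound 4 (the limit leaves the size open). Compound 4 is estimated at 50000 nM, with a range from 30000 nM to 100000 nM.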

Compound 4, concentration lethal to 50% of the cells: 2920 nM
Estimate against measurement, compound 4: 17-fold (1.23 log units) above; measured number outside the range, below it.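

In this assay, within the data shown here, compound 4 is the first compound with a number and not a limit, and on this carbonyl carbon (3-(trifluoromethyl)phenyl)amino in place of 3-(trifluoromethyl)phenyl gives an at least 17-fold lower number from compound 2 to compound 4 (1.23 log units; beyond the scatter) in this series. The amino group is not enough by itself: with it in place, methyl in place of hydrogen on an oxygen on an aromatic ring gives an at least 11-fold lower number from compound 1 to compound 4 (1.04 log units; beyond the scatter) and so the lower number appears only where both changes are present. Compound 3 also carries the amino group and the free hydroxyl and stays at a limit of the assay.

From the compounds shown here alone, whether an ethyl group on that oxygen, or a methyl group on the new amino nitrogen, would keep the lower number remains open. Nothing shown gives a cause for either step.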